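The source may report more compounds than this note shows. Statements on the series, on what has been measured and on what is new or still open speak of the compounds shown alone.

In a functional assay on A549 cells (Homo sapiens) for antiproliferative activity, read by MTT assay, with a stated time of 72 h (a higher number here means a weaker inhibitor, a lower number a stronger inhibitor), compound 1 `COc1ccc(-c2ccc3ncn(-c4cc(OC)c(OC)c(OC)c4)c3c2)cc1F` gives 1430 nM. Compound 2 `COc1cc(-n2cnc3ccc(-c4ccccc4)cc32)cc(OC)c1OC` gives 3060 nM, the higher of the two numbers, which makes it the weaker inhibitor of the pair. Compound 3 `COc1cc(-n2cnc3ccc(-c4cccc(Cl)c4)cc32)cc(OC)c1OC` changes compound 2 on its phenyl group, which becomes 3-chlorophenyl: chloro in place of hydrogen on an aromatic carbon. Among the compounds with values here, one measured step bears on this change, a 2.1-fold higher number from compound 1 to compound 2 (0.33 log units; beyond the scatter), which is modest and came with phenyl in place of 3-fluoro-4-methoxyphenyl on an aromatic carbon. Within the data shown here, that step suggests a substituted phenyl may give a somewhat lower number than the bare phenyl, but no measurement yet shows what chloro does on its own. A modest fall in the number is therefore expected in this assay, with the estimated step being a 1.5-fold lower number from compound 2 to compound 3 (0.16 log units; within the scatter). Compound 3 is estimated at 2100 nM, with an expected range of 900 nM to 4800 nM.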

Compound 3, half-maximal inhibitory concentration: 7050 nM
For compound 3 the middle estimate is 3.4-fold (0.53 log units) below the measured one, outside the stated range (above it).
By their numbers in this assay, from the lowest: compound 1; then compound 2; then compound 3.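

Chloro in place of hydrogen on an aromatic carbon, the first change in this series made at a single place on the bare phenyl group, gives a 2.3-fold higher number from compound 2 to compound 3 (0.36 log units; beyond the scatter) in this assay and so moves the number up, not down. With a 4.9-fold higher number from compound 1 to compound 3 (0.69 log units; beyond the scatter) as well, the bare phenyl of compound 2 falls between the two substituted rings, so a substituent on this ring does not by itself give a lower number: compound 1 lies below compound 2, while compound 3 lies above it. Nothing available here explains the rise from chloro.

As far as these compounds go, whether an amine or a hydroxyl group on the same carbon would shift the number in the same direction as chloro remains open. Also open, from the compounds shown here alone, is how much of the lower number of compound 1 belongs to its fluoro group and how much to its methoxy group.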